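This account rests on a few compounds, and the source may have more. Where it says the series, first, only, none or still open, it means among the compounds named here.

Measured so far:
compound 1, `CCOCCNc1nc(N)nc2ccn(Cc3ccccn3)c12` — > 24000 nM
compound 2, `Cc1cnc(CNc2nc(N)nc3ccn(Cc4ccccn4)c23)o1` — > 24000 nM

In an ADME assay on HEK293 cells (Homo sapiens) for cytotoxicity, read by ATP content, with a stated time of 6 h (on this read-out lower numbers stand for higher toxicity in this test and higher numbers for lower toxicity in this test), compound 1 gives > 24000 nM, which is a limit of the assay and not a number. In this assay compound 2 gives > 24000 nM, again a limit. Among the compounds with values here, the one measured step, a step that the two limits leave unreadable from compound 1 to compound 2, therefore cannot be read in size or direction. Compound 2 stands where every value shown stands, at the limit of > 24000 nM in this assay, at which 2 of the 2 values shown sit.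

Compound 3, `Cc1cnc(COc2nc(N)nc3ccn(Cc4ccccn4)c23)o1`, differs from compound 2 in one place: (5-methyl-1,3-oxazol-2-yl)methoxy in place of ((5-methyl-1,3-oxazol-2-yl)methyl)amino on an aromatic carbon. No measured step touches this part of the core, and the only step shown is unreadable, so there is nothing to set a size for the change to compound 3. Compound 3 is expected to sit at the same limit, with a step that the limit leaves unreadable from compound 2 to compound 3 as the expected step, meaning no step beyond the scatter. The estimate for compound 3 in this assay is 30000 nM, within 12000 nM to 80000 nM.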

Compound 3, half-maximal cytotoxic concentration: > 24000 nM
Compound 3: a limit, no number; the forecaster's own chance of this, stated with the estimate: 85%; the middle value does not contradict the limit.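

In this assay compound 3 gives > 24000 nM, a limit of the assay and not a number, so the steps to it from compound 1 and compound 2 cannot be read. How far these three compounds lie from one another stays open: the limit of > 24000 nM in this assay, at which 3 of the 3 values shown sit.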